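The compounds below may be only part of what the source reports. "The series", "measured", "known", "first", "only" and "open" are said of these compounds alone.

Within the data shown here, in an ADME assay on microsomes from liver (Rattus norvegicus) for metabolic stability, using NADPH, with a stated time of 10 min (on this read-out higher numbers stand for a more stable compound and lower numbers for a less stable compound), compound 1 `CCCCc1nc(=O)c(S(=O)(=O)c2ccc(-c3cccnc3)cc2)c(O)n1-c1c(OC)cccc1OC` gives 3% as the only number available, which places it near the bottom of the scale after the stated incubation time. Compound 2 `CCCCc1[nH]c(=O)c(S(=O)(=O)c2ccc(-c3cccnc3OC)cc2)c(O)c1-c1c(OC)cccc1OC` has the entry "not determined" (no result reported) and so offers no comparison. On this evidence, compound 1 can be called poorly stable, but it cannot be ranked against any other compound.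

The next compound to be tested, compound 3 `CCCCc1nc(=O)c(S(=O)(=O)c2ccc(C3CC3)cc2)c(O)n1-c1c(OC)cccc1OC`, changes a single group on the core of compound 1. The change is cyclopropyl in place of pyridin-3-yl on an aromatic carbon and amounts to cyclopropyl in place of pyridin-3-yl on an aromatic carbon, para to a large group.

Among the measured compounds shown here, no pair of measured compounds shows what a swap like this does, so any forecast here is uncertain. A further fall has little room because compound 1 stands at 3% on this read-out, so any change large enough to notice is expected to be upward. The estimated change is small, an expected a number 3 percentage points higher from compound 1 to compound 3 (within the scatter) in this assay that may not stand clear of the usual scatter. For compound 3 the expected value is 6% with an estimated range from 1% to 22% in this measurement.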

Compound 3, percent of the compound remaining: 59%
For compound 3 the middle estimate is 53 percentage points below the measured one; measured number outside the range, above it.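

In this assay, cyclopropyl in place of pyridin-3-yl on an aromatic carbon, para to a large group, gives a number 56 percentage points higher from compound 1 to compound 3 (beyond the scatter) and shows that this place on the molecule has a strong bearing on the read-out. The low number of compound 1 is therefore not set by the shared core alone, since a change in this one group moves the result well past the usual scatter. However, the swap changes several things at once, including ring size, aromatic character and the presence of a ring nitrogen, and no measurement shown here separates them or explains the rise.

The compounds shown leave open whether a plain phenyl ring, which would keep the six-membered aromatic ring without its nitrogen, would behave more like pyridin-3-yl or like cyclopropyl. Going by these compounds, it also remains open whether a cyclobutyl ring, a longer chain such as n-butyl or an amine such as morpholine at the same place would hold, raise or lower the number seen with cyclopropyl.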